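The source may report more compounds than this note shows. Statements on the series, on what has been measured and on what is new or still open speak of the compounds shown alone.

In a functional assay on MDA-MB-231 cells (Homo sapiens) for inhibition, read by microscopy and colony formation, with a stated time of 10 days (a lower number here means a stronger inhibitor, a higher number a weaker inhibitor), compound 1 (`CCCCCCCCCCCCCCNC(=O)[C@H](CO)NCc1ccccc1`) gives 10500 nM and compound 2 (`CCCCCCCCCCCCCCNC(=O)[C@H](CO)NC(=O)c1cc(OC)cc(OC)c1`) gives 6600 nM as its half-maximal inhibitory concentration. These two numbers lie within the usual scatter of each other, so compound 2 stands level with compound 1, and neither can be ranked as the better inhibitor. Compound 3 (`CCCCCCCCCCCCCCNC(=O)[C@H](CO)NC(C)=O`) has not yet been measured. It differs from compound 2 by having methyl in place of 3,5-dimethoxyphenyl on a carbonyl carbon. Among the compounds with values here, no measured pair shows what such a swap does in this assay, so the expectation is cautious: a small move toward a weaker inhibitor, perhaps no larger than the scatter. The estimated step is a 1.4-fold higher number from compound 2 to compound 3 (0.16 log units; within the scatter) and remains a rough guess. For compound 3 the estimated value is 9500 nM (expected range 3500 nM to 26000 nM).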

Compound 3, half-maximal inhibitory concentration: 75100 nM
For compound 3 the middle estimate is 7.9-fold (0.90 log units) below the measured one; measured number outside the range, above it.
By their numbers in this assay, from the lowest: compounds 2 and 1 (each within the scatter of the next); then compound 3.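

In this assay the group on this carbonyl carbon clearly matters: methyl in place of 3,5-dimethoxyphenyl gives an 11-fold higher number from compound 2 to compound 3 (1.06 log units; beyond the scatter) and is a large change, well beyond the scatter. Acetyl in place of benzyl on the amine nitrogen gives a 7.2-fold higher number from compound 1 to compound 3 (0.85 log units; beyond the scatter) and also lies beyond the scatter, so compound 3, the only one of the three without an aromatic ring, stands apart from two compounds that sit level with each other. Nothing available explains this loss of inhibition.

Whether the ring itself or its methoxy groups account for the difference stays open, and a plain phenyl on this carbonyl carbon would help separate the two. It is also unknown how a group of intermediate size, such as cyclohexyl, would behave in this place.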